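The source may hold more compounds than are shown below. What is called first, only, known or untested is meant among the compounds shown, and "the series" means these compounds.

The measured compounds: compound 1 `O=c1cc(-c2ccccc2)oc2c(OCCCN3CCCC3)c(OCc3ccccc3)cc(O)c12`, which in a functional assay on B16 cells (Mus musculus) for cytotoxicity, read by MTT assay, with a stated time of 72 h (a higher number here means a weaker inhibitor, a lower number a stronger inhibitor), gives 7980 nM; compound 2 `CCN(CC)CCCCOc1c(OCc2ccccc2)cc(O)c2c(=O)cc(-c3ccccc3)oc12`, which in this assay gives 4880 nM.

For the measured compounds named here, compound 2 holds the lowest of the two numbers, but its only neighbour is compound 1, and the step of a 1.6-fold lower number from compound 1 to compound 2 (0.21 log units; within the scatter) is within the scatter, so the two are not told apart by these data. Compound 3 `CN1CCN(CCCCOc2c(OCc3ccccc3)cc(O)c3c(=O)cc(-c4ccccc4)oc23)CC1` has not been measured; it differs from compound 2 by 4-methylpiperazin-1-yl in place of diethylamino on a saturated chain carbon, four bonds along the chain from an oxygen on an aromatic ring. Going by the values given here, the only step that bears on it is the exchange of one amine for another between compound 1 and compound 2, a 1.6-fold lower number from compound 1 to compound 2 (0.21 log units; within the scatter), which stayed within the scatter. A further exchange of amine is therefore expected to give no step beyond the scatter, that is a 1.0-fold higher number from compound 2 to compound 3 (0.01 log units; within the scatter). Compound 3 is expected to give about 5000 nM, in the range 2000 nM to 13000 nM.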

Compound 3, half-maximal inhibitory concentration: 2370 nM
The estimate for compound 3 lay 2.1-fold (0.32 log units) above the measured number, and the stated range covers the measured number.
By their numbers in this assay, from the lowest: compound 3; then compounds 2 and 1 (each within the scatter of the next).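

In this assay, the earlier exchange of one amine for another stayed within the scatter, but this position does respond to the choice of amine: 4-methylpiperazin-1-yl in place of diethylamino gives a 2.1-fold lower number from compound 2 to compound 3 (0.31 log units; beyond the scatter), a step beyond the scatter. The wider comparison, (4-methylpiperazin-1-yl)methyl in place of pyrrolidin-1-yl, gives a 3.4-fold lower number from compound 1 to compound 3 (0.53 log units; beyond the scatter), also beyond the scatter, though both steps remain modest. Nothing given here accounts for these steps.

The compounds shown leave open whether the ring or its second nitrogen goes with the lower number, and a piperidin-1-yl or morpholin-4-yl group at this place would separate the two. They also leave open how piperazin-1-yl, or the same 4-methylpiperazin-1-yl on a longer chain, would read in this assay.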